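This account rests on a few compounds, and the source may have more. Where it says the series, first, only, none or still open, it means among the compounds named here.

Of the compounds shown here, three have so far been tested in a functional assay on RAW264.7 cells (Mus musculus) for inhibition, read by Griess assay, with a stated time of 20 h (a higher number here means a weaker inhibitor, a lower number a stronger inhibitor), and none of them has yet given an exact number. Compound 1 `CCCNC(=O)c1cc(-n2cc(-c3cc(C(F)(F)F)cc(C(F)(F)F)c3)nn2)ccc1O` reads > 20000 nM, which is a limit of the assay. Compound 2 `O=C(c1cc(-n2cc(-c3ccccc3)nn2)ccc1O)N1CCCCC1` reads > 20000 nM, which is again a limit. Compound 3 `CCCNC(=O)c1ccc(-n2cc(-c3ccccc3)nn2)cc1O` reads > 20000 nM, and this too is a limit. The whole set therefore stands at one place on the scale: the limit of > 20000 nM in this assay, at which 3 of the 3 values shown sit.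

The next compound to follow is compound 4 `CCCNC(=O)c1ccc(-n2cc(-c3cc(F)cc(F)c3)nn2)cc1O`, which differs from compound 3 in one place. It carries 3,5-difluorophenyl in place of phenyl on an aromatic carbon.

Among the compounds with values here, no two tested compounds differ in only one place, so no measured step shows how large such a change might be. In this assay, no step beyond the scatter is expected, in either direction. That expectation rests on compound 3, whose reading of > 20000 nM is a limit and offers no exact number to start from. The estimated change is small, as the expected step of a number no higher from compound 3 to compound 4 (the limit leaves the size open) shows. A reading at the same limit is the most likely outcome. The estimate for compound 4 is 20000 nM, with an expected range from 9000 nM to 40000 nM.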

Compound 4, half-maximal inhibitory concentration: > 20000 nM
Compound 4: only a limit was reported (the forecaster's own chance of this, stated with the estimate: 75%); the middle value lies on the limit itself.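

In this assay, within the data shown here, compound 3 and compound 4 each give only a limit, so no step between them can be read. The compounds shown leave open what exact value any of them would have, and whether any change to the shared core would give a measurable inhibition, because all of them sit at one place: the limit of > 20000 nM in this assay, at which 4 of the 4 values shown sit.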